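Cyclopropyl to furan-2-yl on the carbonyl

A few compounds are considered here, and "the series" means these few. Any claim that something is new, unique, unknown or untested is made for them only; others in the source may bear on it.

compound 1 `COc1ccc(/C=C/C(=O)c2ccc(OC)c3c2OC(C)(C)C=C3)cc1OCC=C(C)C` | > 10000 nM
compound 2 `COc1ccc(/C=C/C(=O)c2ccc(OC)c3c2OC(C)(C)C=C3)cc1OC(=O)C1CC1` | 380 nM

In a functional assay on A-375 cells (Homo sapiens) for cytotoxicity, read by MTT assay (a lower number here means a stronger inhibitor, a higher number a weaker inhibitor), compound 1 gives only a limit, > 10000 nM. Among the measured compounds shown here, compound 2, at 380 nM, holds the only true number so far. Compound 3 `COc1ccc(/C=C/C(=O)c2ccc(OC)c3c2OC(C)(C)C=C3)cc1OC(=O)c1ccco1` differs from compound 2 as follows: furan-2-yl in place of cyclopropyl on a carbonyl carbon. For the measured compounds named here, compound 3 keeps the carbonyl, and the only measured step, an at least 26-fold lower number from compound 1 to compound 2 (1.42 log units; beyond the scatter), brought that carbonyl in, so a much smaller change is expected here, probably towards a somewhat weaker inhibitor. The expected size is a 1.6-fold higher number from compound 2 to compound 3 (0.20 log units; within the scatter), which may not exceed the scatter. For compound 3 the estimate is 600 nM, with an expected range of 150 nM to 3000 nM.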

Compound 3, half-maximal inhibitory concentration: 680 nM
Beside the measured number, compound 3's estimate is 1.1-fold (0.05 log units) below it, and the stated range covers the measured number.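

In this assay, furan-2-yl in place of cyclopropyl on the carbonyl carbon gives a 1.8-fold higher number from compound 2 to compound 3 (0.25 log units; within the scatter), so this position tolerates a five-membered aromatic ring as well as a three-membered non-aromatic one. The (furan-2-yl)carbonyl group also gives an at least 14-fold lower number from compound 1 to compound 3 (1.16 log units; beyond the scatter), so the large step is no longer tied to cyclopropylcarbonyl alone. Compound 1 sits at a limit of the assay, so the full size of that step stays open: the limit of > 10000 nM in this assay, at which 1 of the 3 values shown sits.

As far as these compounds go, whether other groups on the carbonyl, such as a longer alkyl chain or an amine-bearing chain, hold this level remains open. So does whether a phenyl ring there would do the same.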